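Adding an ethyl group to the chain of compound 2

The source may hold more compounds than are shown below. What is called first, only, known or untested is meant among the compounds shown, and "the series" means these compounds.

Measured in an ADME assay on the whole organism (Mus musculus, strain CD1) for pharmacokinetics, read by LC-MS, with a stated time of 24 h, at a dose of 5 mg/kg by the oral route; a higher number here means more compound in the circulation at the dose given, a lower number less compound in the circulation:
- compound 1 `O=C(O)Cn1nc(Cc2nc3cc(Cl)c(OCC(F)F)cc3[nH]2)c2ccccc2c1=O`: 55 ng.h/mL
- compound 2 `O=C(O)Cc1nn(Cc2cn3cc(OCC4CC4)c(Cl)cc3n2)c2ccccc2c1=O`: 968 ng.h/mL

Of these two, compound 2 stands highest, and compound 1 lies lower, with a gap beyond the usual scatter. Compound 3 `CCC(C(=O)O)c1nn(Cc2cn3cc(OCC4CC4)c(Cl)cc3n2)c2ccccc2c1=O` keeps the core of compound 2 and changes one group: ethyl in place of hydrogen on a saturated chain carbon bound to an aromatic carbon and a carbonyl carbon. This puts ethyl in place of hydrogen on a saturated chain carbon bound to an aromatic carbon and a carbonyl carbon, turning carboxymethyl into 1-carboxypropyl. Among the measured compounds shown here, no measured pair shows what a single change of this kind does in this assay, so the expectation rests only on compound 2 at 968 ng.h/mL: a small upward move, probably none beyond the scatter. The expected change is a 1.5-fold higher number from compound 2 to compound 3 (0.19 log units; within the scatter). For compound 3 the estimate is 1500 ng.h/mL, with an expected range from 400 ng.h/mL to 5000 ng.h/mL.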

Compound 3, area under the concentration-time curve: 1260 ng.h/mL
For compound 3 the middle estimate is 1.2-fold (0.08 log units) above the measured one; the range from low to high includes it.
By their numbers in this assay, from the lowest: compound 1; then compounds 2 and 3 (each within the scatter of the next).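

In this assay, among the compounds shown here, putting ethyl in place of hydrogen on a saturated chain carbon bound to an aromatic carbon and a carbonyl carbon gives a 1.3-fold higher number from compound 2 to compound 3 (0.11 log units; within the scatter), the first step that isolates a single change. Turning carboxymethyl into 1-carboxypropyl therefore leaves the reading within the scatter, so this chain carbon can carry ethyl without a measurable shift in this assay. No supporting measurement bears on why the reading holds at this position.

The compounds shown leave open whether a methyl group or a longer chain such as propyl on this same carbon would also stay within the scatter. They also leave open how ethyl at this carbon would read if a primary amide stood in place of the carboxylic acid.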